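The source may report more compounds than this note shows. Statements on the series, on what has been measured and on what is new or still open speak of the compounds shown alone.

Of the compounds shown here, three have so far been measured in a functional assay on MM1.S cells (Homo sapiens) for cytotoxicity, read by MTT assay, with a stated time of 72 h, tested at 10 uM; a lower number here means less inhibition, a higher number more inhibition at the concentration tested (going by the name of the read-out). Compound 1 `C[C@H](NC(=O)/C(C#N)=C/c1cccnc1)c1ccccc1` gives 44% there, and compound 3 `C[C@H](NC(=O)/C(C#N)=C/c1cccc(/C=C(\C#N)C(=O)N[C@@H](C)c2ccccc2)c1)c1ccccc1` gives 100%. Compound 2 `CCCCOc1ccc(/C=C(\C#N)C(=O)N[C@@H](C)c2ccccc2)cc1` gives 31% in this assay, the lowest of the three numbers; compound 1 stands nearest to it and compound 3 furthest, both gaps beyond the usual scatter of such measurements. Compound 4 `C[C@H](NC(=O)/C(C#N)=C/c1ccc(-c2ccccc2)cc1)c1ccccc1` has not yet been measured in this assay. It differs from compound 2 in one place: phenyl in place of butoxy on an aromatic carbon. The incoming group sits on an aromatic carbon of a six-membered aromatic ring of carbon only, para to a large group. For the measured compounds named here, no pair of measured compounds differs in one place, so nothing among them shows what such an exchange does, and the expectation rests on the number for compound 2 alone. Compound 4 is therefore expected to give about 40% in this assay, somewhere between 15% and 70%. The step of a number 9 percentage points higher from compound 2 to compound 4 (within the scatter) that this estimate means is expected to be small, not clearly beyond the scatter in either direction.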

Compound 4, a percentage reported as inhibition, at one concentration (the size of the read-out at that concentration, not a potency): 49%
Estimate against measurement, compound 4: 9 percentage points below; the range from low to high includes it.
By their numbers in this assay, from the lowest: compound 2; then compounds 1 and 4 (each within the scatter of the next); then compound 3.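

In this assay, for the compounds shown here, phenyl in place of butoxy on an aromatic carbon, para to a large group, gives the first step between two compounds differing in one place, with a number 18 percentage points higher from compound 2 to compound 4 (beyond the scatter) as the result. This step is modest, but it shows that the read-out at this position responds to the group it carries, and that an aromatic ring can replace the open chain without any fall in the number. Nothing available explains this step.

On these data alone, whether the rise goes with the aromatic ring itself or with the loss of the butoxy chain stays open. It also remains to be seen whether a cyclohexyl ring, a shorter alkoxy chain or an amine on this carbon would read like phenyl or like butoxy.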